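The source may hold more compounds than are shown below. What is called first, only, known or untested is meant among the compounds shown, and "the series" means these compounds.

The study measures cytotoxicity in an ADME assay on Raji cells (Homo sapiens) for cytotoxicity, with a stated time of 72 h; a lower number here means that less compound is needed, a higher number that more compound is needed for the effect. Within the data shown here, compound 1 `Cc1cc(NC(=O)Nc2cccc(Cl)c2)c2ccccc2n1` gives 18000 nM there, and that is the only plain number among the three values shown. The other two values are limits (the limit of > 25000 nM in this assay, at which 2 of the 3 values shown sit). Compound 2 `Cc1cc(NC(=O)Nc2ccc(F)cc2)c2ccccc2n1` reaches only the limit of > 25000 nM in this assay. Compound 3 `Cc1cc(NC(=O)Nc2cc(Cl)cc(Cl)c2)c2ccccc2n1` likewise reaches only the limit of > 25000 nM. The steps of an at least 1.3-fold higher number from compound 1 to compound 2 (0.14 log units; that floor lies within the scatter) and an at least 1.3-fold higher number from compound 1 to compound 3 (0.14 log units; that floor lies within the scatter) both end at a limit, so their true size is not known beyond the stated floor. Compound 4 `Cc1cc(NC(=O)Nc2cccc(OC(F)(F)F)c2)c2ccccc2n1` differs from compound 1 in one place: trifluoromethoxy in place of chloro on an aromatic carbon. Among the measured compounds shown here, no measured step makes this exact change, but both measured steps alter the same part of compound 1 and both moved to a limit, so a small step toward a higher number, or none beyond the scatter, is expected here. Compound 4 is therefore expected to show a 1.3-fold higher number from compound 1 to compound 4 (0.12 log units; within the scatter). Compound 4 is estimated at 24000 nM, with a range from 10000 nM to 55000 nM.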

Compound 4, half-maximal effective concentration: 9000 nM
For compound 4 the middle estimate is 2.7-fold (0.43 log units) above the measured one; measured number below the stated range.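

At this place, on an aromatic carbon meta to a large group, trifluoromethoxy in place of chloro gives a 2.0-fold lower number from compound 1 to compound 4 (0.30 log units; within the scatter), so in this assay the two compounds cannot be told apart, although the entering group holds 5 heavy atoms and the leaving one holds 1. This is the first step shown that joins two plain numbers, and thus the first whose size can be read rather than only bounded by a floor. Compound 4 does not join the compounds that sit at a limit: the limit of > 25000 nM in this assay, at which 2 of the 4 values shown sit.

The compounds shown leave open what an amine, a carboxylic acid or a longer chain would give at this same place, and what any change on the shared core would give. As far as these compounds go, how far compound 2 and compound 3 truly lie from compound 1 also stays open.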